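The source may report more compounds than this note shows. Statements on the series, on what has been measured and on what is new or still open speak of the compounds shown alone.

Compound 1 `C/C=C/C(=O)N(Cc1ccc(OC)c(OC)c1)c1cc(OC)c(OC)c(OC)c1` in a functional assay on KYSE-450 cells (Homo sapiens) for inhibition, read by MTT assay, with a stated time of 48 h; on this read-out lower numbers stand for stronger inhibition and higher numbers for weaker inhibition: 39100 nM.
Compound 2 `COc1ccc(CNc2cc(OC)c(OC)c(OC)c2)cc1F` in this assay: 46200 nM.
Compound 3 `COc1ccc(CNc2cc(OC)c(OC)c(OC)c2)cc1C` in this assay: 73800 nM.

Among these three, compound 1 gives the lowest number, yet each of the other two sits within the usual scatter of it, so no order of potency can be read from them. Among the measured compounds shown here, the only single-point step measured here, a 1.6-fold higher number from compound 2 to compound 3 (0.20 log units; within the scatter), swaps methyl in place of fluoro on an aromatic carbon and also stays within the scatter.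

Compound 4 `C/C=C/C(=O)N(Cc1ccc(OC)c(O)c1)c1cc(OC)c(OC)c(OC)c1` differs from compound 1 in one place: hydrogen in place of methyl on an oxygen on an aromatic ring. For the measured compounds named here, no measured pair shows this kind of change, and the step of a 1.6-fold higher number from compound 2 to compound 3 (0.20 log units; within the scatter) concerns a different group on a different kind of atom, so it does not bear on it. With nothing in the data pointing either way, compound 4 is expected to come out close to compound 1 in this assay, which amounts to a 1.1-fold lower number from compound 1 to compound 4 (0.05 log units; within the scatter). The estimate for compound 4 is 35000 nM, with a range from 12000 nM to 100000 nM.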

Compound 4, half-maximal inhibitory concentration: 67 nM
Beside the measured number, compound 4's estimate is 520-fold (2.72 log units) above it; measured number below the stated range.
By their numbers in this assay, from the lowest: compound 4; then compounds 1, 2 and 3 (each within the scatter of the next).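

In this assay this position proves highly sensitive: going from methoxy to hydroxy on the aromatic ring gives a 580-fold lower number from compound 1 to compound 4 (2.77 log units; beyond the scatter), although only a methyl group of 1 heavy atom leaves and a hydrogen enters. The three earlier compounds all lay within the scatter of one another, so they gave no sign that a change in one place could move the number this far. Nothing shown here explains the size of this step.

On these data alone, it remains open whether the free hydroxy group itself is what matters, which an ethoxy group, an amino group or a carboxylic acid in the same place could help to test. As far as these compounds go, it is also open whether the same change would have a similar effect on the other methoxy groups of the shared core.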